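A few compounds are considered here, and "the series" means these few. Any claim that something is new, unique, unknown or untested is made for them only; others in the source may bear on it.

Measured in a functional assay on HCT-116 cells (Homo sapiens) for antiproliferative activity, read by MTT assay, with a stated time of 48 h; on this read-out lower numbers stand for stronger inhibition and higher numbers for weaker inhibition:
- Compound 1 `CCCC(CCO)n1cnc2c(Cl)ncnc21`: > 50000 nM, a limit of the assay
- Compound 2 `CCCCCCCC(CCO)n1cnc2c(Cl)ncnc21`: 4160 nM
- Compound 3 `CCCCCCCCC(CCO)n1cnc2c(Cl)ncnc21`: 1650 nM

Among these three compounds, compound 3 stands lowest, at 1650 nM. Its nearest neighbour is compound 2 at 4160 nM. Compound 4 `CCCCCCCCCCC(CCO)n1cnc2c(Cl)ncnc21` has not yet been measured. Its structure departs from that of compound 3 as follows: ethyl in place of hydrogen on a saturated chain carbon, nine bonds along the chain from an aromatic nitrogen.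

The closest guide is the modest step of a 2.5-fold lower number from compound 2 to compound 3 (0.40 log units; beyond the scatter), which lies beyond the scatter and comes from a methyl in place of hydrogen further along the same chain. The large steps of an at least 12-fold lower number from compound 1 to compound 2 (1.07 log units; beyond the scatter) and an at least 30-fold lower number from compound 1 to compound 3 (1.48 log units; beyond the scatter) run in the same direction. Both of these start from the limit of compound 1. Across all three compounds, a longer chain goes with a lower number, and none of them goes against this. The data do not show whether the trend continues past compound 3, so a further modest fall in this assay is expected, with real uncertainty about its size. The estimate is a 2.2-fold lower number from compound 3 to compound 4 (0.34 log units; beyond the scatter), an expected modest step to a lower number. Compound 4 is expected to give 750 nM, with an estimated range of 200 nM to 2500 nM.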

Compound 4, half-maximal inhibitory concentration: 4930 nM
The estimate for compound 4 lay 6.6-fold (0.82 log units) below the measured number, outside the stated range (above it).
By their numbers in this assay, from the lowest: compound 3; then compounds 2 and 4 (each within the scatter of the next). At a limit, above all of these: compound 1.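

In this assay, a longer chain at this position no longer goes with a lower number: ethyl in place of hydrogen, on a saturated chain carbon, nine bonds along the chain from an aromatic nitrogen, gives a 3.0-fold higher number from compound 3 to compound 4 (0.48 log units; beyond the scatter) and so reverses the fall seen up to compound 3, which now holds the lowest number among the measured values. The gain does not merely level off, since a 1.2-fold higher number from compound 2 to compound 4 (0.07 log units; within the scatter) places compound 2 and compound 4 on a par, and the low number of compound 3 therefore belongs to one chain length in this short series, not to long chains in general. Compound 1 remains a limit of the assay at > 50000 nM, so an at least 10-fold lower number from compound 1 to compound 4 (1.00 log units; beyond the scatter) gives a bound and not a measured size: the limit of > 50000 nM in this assay, at which 1 of the 4 values shown sits.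

The compounds shown leave open whether a still longer chain would hold the number near that of compound 4 or raise it further, and they give no reason for the rise. They also leave open whether an amine or a carboxylic acid in place of the hydroxyl would keep the same dependence on chain length.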